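This account rests on a few compounds, and the source may have more. Where it says the series, first, only, none or still open, it means among the compounds named here.

Of the compounds shown here, two built on a shared core have been tested in an in vitro ADME assay on microsomes from liver (Homo sapiens) for metabolic stability, read by LC-MS; a lower number here means that the compound disappears faster, a higher number that the compound lasts longer. Compound 1 `CON/C(=N\C1=NC(=O)C(=O)N1C(C)C)Nc1ccc(Cl)c(Cl)c1` gives > 1 h, which is a limit of the assay rather than a number. Within the data shown here, compound 2 `CC(C)N1C(=O)C(=O)N=C1/N=C(\NOCc1ccccc1)Nc1ccc(Cl)c(Cl)c1` gives 0.215 h, the only plain number available so far. The other value shown is the limit of > 1 h in this assay, at which 1 of the 2 values shown sits, and it belongs to compound 1. Among the measured compounds shown here, the single measured step, an at least 4.6-fold lower number from compound 1 to compound 2 (0.66 log units; beyond the scatter), came with a phenyl in place of hydrogen on a saturated chain carbon bound to an oxygen. Compound 3 `CN/C(=N\C1=NC(=O)C(=O)N1C(C)C)Nc1ccc(Cl)c(Cl)c1` differs from compound 2 by methyl in place of benzyloxy on an amine nitrogen. For the measured compounds named here, this change takes away the entire benzyloxy group, including the phenyl whose arrival marked the only measured step, so that step is the one that bears on it and its direction is expected to reverse. For compound 3 the expected step is a 5.6-fold higher number from compound 2 to compound 3 (0.75 log units; beyond the scatter), toward a longer half-life. The estimate for compound 3 in this assay is 1.2 h, within a range from 0.5 h to 3 h, and a reading that is again only a limit would not be surprising.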

Compound 3, half-life: > 1 h
Compound 3 ended at the assay's limit (the forecaster's own chance of this, stated with the estimate: 50%); the middle value is on the limit's open side.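

Replacing the benzyloxy group on the amine nitrogen with methyl gives, in this assay, an at least 4.6-fold higher number from compound 2 to compound 3 (0.66 log units; beyond the scatter). This second comparison shows that the oxygen on that nitrogen does not by itself set compound 2 apart: compound 1 carries methoxy there, compound 3 carries methyl with no oxygen at that point, and both read as limits of the assay rather than numbers, while only compound 2, with its phenyl ring, gives a plain half-life. The step from compound 1 to compound 3 cannot be read, because both compounds rest at the same limit, so methoxy and methyl cannot be ordered here: the limit of > 1 h in this assay, at which 2 of the 3 values shown sit.

The compounds shown leave open whether the phenyl ring itself matters or whether any longer chain on this nitrogen would shorten the half-life too, a question that a butoxy or cyclohexylmethoxy group in the same place could address. On these data alone, how long compound 1 and compound 3 really last also stays unknown, and with it the full size of the change from benzyloxy to methyl.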